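Amine exchange on the thiocarbonyl carbon, compound 1 to compound 4

This account rests on a few compounds, and the source may have more. Where it says the series, first, only, none or still open, it means among the compounds named here.

Three compounds of the series carry a measured value. Compound 1 `CC1CCCCN1C(=S)SCc1ccc(C(=O)Nc2ccccc2N)cc1` gives 85.2% in a functional assay on A-375 cells (Homo sapiens) for antiproliferative activity, read by CCK-8 assay, with a stated time of 72 h, tested at 8 uM; on this read-out lower numbers stand for a weaker effect and higher numbers for a stronger effect at the one concentration tested. Compound 3 `Nc1ccccc1NC(=O)c1ccc(CSC(=S)N2CCN(c3cnccn3)CC2)cc1` gives 85.8% in this assay, a value within the scatter of that of compound 1, so the two cannot be ordered. Compound 2 `Nc1ccccc1NC(=O)c1ccc(CSC(=S)N2CCN(C(c3ccccc3)c3ccccc3)CC2)cc1` gives 8.4% in this assay, far below both and beyond the scatter. Compound 1 thus stands second of the three numbers, separated from compound 3 by nothing the scatter would resolve and from compound 2 by a wide margin.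

The step considered leads to compound 4 `Nc1ccccc1NC(=O)c1ccc(CSC(=S)N2CCCC2)cc1`, not yet measured. Compound 4 differs from compound 1 in one place: pyrrolidin-1-yl in place of 2-methylpiperidin-1-yl on a thiocarbonyl carbon. Among the measured compounds shown here, no pair of measured compounds differs in a single place, so no measured step sets the size. The two high values, compound 1 with 85.2% and compound 3 with 85.8%, both sit near the top of the range, and the change is a exchange of one saturated ring amine for another on the thiocarbonyl carbon. The expected step in this assay is therefore none beyond the scatter, or at most a modest decrease. The estimate for compound 4 is 78%, within 55% to 92%. This corresponds to an expected step of a number 7.2 percentage points lower from compound 1 to compound 4 (within the scatter).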

Compound 4, a percentage reported as inhibition, at one concentration (the size of the read-out at that concentration, not a potency): 89.5%
Compound 4: middle estimate off by 11.5 percentage points, on the low side; the range from low to high includes it.
By their numbers in this assay, from the lowest: compound 2; then compounds 1, 3 and 4 (each within the scatter of the next).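

Among the compounds shown here, the exchange of 2-methylpiperidin-1-yl for pyrrolidin-1-yl on a thiocarbonyl carbon supplies the first single-place comparison: in this assay, the step is a number 4.3 percentage points higher from compound 1 to compound 4 (within the scatter). At this position, therefore, a six-membered non-aromatic ring carrying a methyl group and an unsubstituted five-membered non-aromatic ring cannot be told apart on this read-out, which reflects the size of the effect at a single concentration and not a potency. No available measurement bears on the reason for this result.

This single exchange changes ring size and removes the methyl group together, so the contribution of each remains unresolved; piperidin-1-yl would separate the two. The compounds shown also leave open whether the result extends beyond saturated ring amines carrying no further hetero atom, for example to morpholin-4-yl or to an open-chain amine such as diethylamino on the same thiocarbonyl carbon.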